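Ester to ether on a shared core: what to expect

The source may report more compounds than this note shows. Statements on the series, on what has been measured and on what is new or still open speak of the compounds shown alone.

For the measured compounds named here, compound 3, `CCC(=O)OCc1c(F)c(N)c2c(=O)cc(-c3ccc(N)c(F)c3)oc2c1F`, is the one member of this small set for which a functional assay on HeLa cells (Homo sapiens) for cytotoxicity, read by neutral red uptake, with a stated time of 3 days (on this read-out higher numbers stand for weaker inhibition and lower numbers for stronger inhibition), reports an actual number: compound 3 gives 69000 nM. Compound 1, `CCCCc1c(F)c(N)c2c(=O)cc(-c3ccc(N)c(F)c3)oc2c1F`, reaches only a limit in this assay, with compound 1 at > 100000 nM. Compound 2, `Nc1ccc(-c2cc(=O)c3c(N)c(F)c(Cl)c(F)c3o2)cc1F`, likewise stops at a limit, with compound 2 at > 100000 nM. So compound 3 stands alone with a number, and the limit of > 100000 nM in this assay, at which 2 of the 3 values shown sit, marks where the other two sit. The step from compound 1 to compound 3 reads an at least 1.4-fold lower number from compound 1 to compound 3 (0.16 log units; that floor lies within the scatter), and that from compound 2 to compound 3 reads an at least 1.4-fold lower number from compound 2 to compound 3 (0.16 log units; that floor lies within the scatter); between compound 1 and compound 2 lies a step that the two limits leave unreadable from compound 1 to compound 2.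

Compound 4, `CCCOCc1c(F)c(N)c2c(=O)cc(-c3ccc(N)c(F)c3)oc2c1F`, differs from compound 3 by propyl in place of propanoyl on an oxygen on a saturated carbon. Going by the values given here, none of the measured steps exchanges an ester for an ether, so none bears directly on this change, and all three measured compounds lie at or close to the limit. The estimated step from compound 3 to compound 4 is therefore a 1.4-fold higher number from compound 3 to compound 4 (0.16 log units; within the scatter), expected to stay within the scatter. Compound 4 is expected to give 100000 nM, with a range from 40000 nM to 300000 nM.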

Compound 4, half-maximal inhibitory concentration: 78000 nM
Compound 4: the middle estimate sits 1.3-fold (0.11 log units) above what was measured, and the stated range covers the measured number.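

In this assay, for the compounds shown here, compound 3 and compound 4 are the first pair in this set that differ in one place and both give an actual number: a 1.1-fold higher number from compound 3 to compound 4 (0.05 log units; within the scatter). Exchanging propanoyl for propyl on this oxygen removes the carbonyl, yet the two numbers stay within the scatter of each other, so the ester is not needed for a measured number at this position. The comparisons with the other two compounds give only floors, an at least 1.2-fold lower number from compound 2 to compound 4 (0.10 log units; that floor lies within the scatter) and an at least 1.2-fold lower number from compound 1 to compound 4 (0.10 log units; that floor lies within the scatter), and they remain floors because of this: the limit of > 100000 nM in this assay, at which 2 of the 4 values shown sit.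

On these data alone, it remains open whether any group on this oxygen can move the number beyond the scatter. A longer chain, or a chain ending in an amine or a carboxylic acid, in place of propyl would test this.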